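Methoxy in Place of Methyl: an Expected Antiproliferative Value

The source may hold more compounds than are shown below. What is called first, only, known or untested is meant among the compounds shown, and "the series" means these compounds.

Measured compounds:
Compound 1, `Nc1cc(F)ccc1NC(=O)c1ccc(COc2ccccc2)cc1`: 8340 nM
Compound 2, `Cc1ccc(OCc2ccc(C(=O)Nc3ccccc3N)cc2)cc1`: 5430 nM

Of the compounds shown here, two have been measured in a functional assay on A549 cells (Homo sapiens) for antiproliferative activity, read by CCK-8 assay, with a stated time of 72 h; on this read-out higher numbers stand for weaker inhibition and lower numbers for stronger inhibition. Compound 1 gives 8340 nM there, and compound 2 gives 5430 nM. Compound 2 has the lower of the two numbers, but the gap to compound 1 lies within the usual scatter of this measurement, so the two cannot be ranked against each other.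

Compound 3, `COc1ccc(OCc2ccc(C(=O)Nc3ccccc3N)cc2)cc1`, differs from compound 2 in one place: methoxy in place of methyl on an aromatic carbon. For the measured compounds named here, no step between measured compounds bears on this kind of exchange, so there is nothing in the measured numbers to argue for a shift in either direction. The step from compound 2 to compound 3 is therefore expected to be small, a 1.1-fold lower number from compound 2 to compound 3 (0.04 log units; within the scatter), and not beyond the scatter.

Compound 3 is accordingly expected to give about 5000 nM in this assay. The estimate for compound 3 is set to run from 2200 nM to 11000 nM.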

Compound 3, half-maximal inhibitory concentration: 5530 nM
Compound 3: the middle estimate sits 1.1-fold (0.04 log units) below what was measured, within the range that was stated.
By their numbers in this assay, from the lowest: compounds 2, 3 and 1 (each within the scatter of the next).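

In this assay the exchange of 4-methylphenyl for 4-methoxyphenyl, on an aromatic carbon para to a large group, reads as a 1.0-fold higher number from compound 2 to compound 3 (0.01 log units; within the scatter) and gives the first direct measure of this change, which compounds 1 and 2 alone could not provide. At this position, then, the extra oxygen and the hydrogen-bond acceptor counted with it leave compound 3 indistinguishable from compound 2 on this read-out. No measurement at hand offers an explanation for this result.

One exchange at one position cannot show how far this tolerance extends. The compounds shown leave open whether an amine, a carboxylic acid or a longer chain such as propoxy at the same place would also stay within the scatter of compound 2 or would move the number beyond it.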